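Methoxy in place of piperazin-1-yl in compound 3

The source may hold more compounds than are shown below. What is called first, only, known or untested is meant among the compounds shown, and "the series" means these compounds.

In an ADME assay on NIH3T3 cells (Mus musculus) for cytotoxicity (on this read-out higher numbers stand for lower toxicity in this test and lower numbers for higher toxicity in this test), compound 3 `Fc1cccc(COc2ccc(Nc3ncnc4cc(C#CCN5CCNCC5)sc34)cc2Cl)c1` gives > 50 uM, which is a limit of the assay and not a number. Compound 4 `COCC#Cc1cc2ncnc(Nc3ccc(OCc4cccc(F)c4)c(Cl)c3)c2s1` differs from it at one place: methoxy in place of piperazin-1-yl on a saturated chain carbon bound to a triple-bonded carbon. The methoxy stands on a saturated chain carbon bound to a triple-bonded carbon.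

Among the compounds with values here, no measured compound carries methoxy there, so the evidence is indirect. Compound 1 `CN1CCN(CC#Cc2cc3ncnc(Nc4ccc(OCc5cccc(F)c5)c(Cl)c4)c3s2)CC1` gives 4.8 uM, and compound 2 `CCOC(=O)CN(C)CC#Cc1cc2ncnc(Nc3ccc(OCc4cccc(F)c4)c(Cl)c3)c2s1` gives 52 uM. Two large steps, both beyond the scatter, start from compound 1: an 11-fold higher number from compound 1 to compound 2 (1.03 log units; beyond the scatter) and an at least 10-fold higher number from compound 1 to compound 3 (1.01 log units; beyond the scatter). The third comparison is a step that the limit leaves unreadable from compound 2 to compound 3.

Compound 4 lacks the 4-methylpiperazin-1-yl group of compound 1, so it is expected to lie nearer compound 2, at 52 uM, than compound 1, at 4.8 uM. The expected outcome is an at least 1.6-fold lower number from compound 3 to compound 4 (0.22 log units; that floor lies within the scatter), a modest move to a lower number if any step can be read. For compound 4 the estimate is 30 uM, with an expected range of 8 uM to 100 uM.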

Compound 4, half-maximal toxic concentration: > 50 uM
Compound 4 gave a limit, no number; the forecaster's own chance of this, stated with the estimate: 35%; middle value at least 1.6-fold (0.22 log units) from the limit.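

In this assay compound 4 gives > 50 uM, which is a limit of the assay and not a number. Methoxy in place of 4-methylpiperazin-1-yl on a saturated chain carbon bound to a triple-bonded carbon gives an at least 10-fold higher number from compound 1 to compound 4 (1.01 log units; beyond the scatter), so at this position the higher number no longer depends on a group that carries nitrogen, as the groups in compound 2 and compound 3 both do. The steps to compound 4 from compound 2 and from compound 3 cannot be read: the limit of > 50 uM in this assay, at which 2 of the 4 values shown sit.

As far as these compounds go, how far the true values of compound 3 and compound 4 lie beyond the limit remains open. Also open, from the compounds shown here alone, is whether a hydroxy group, a carboxylic acid or a longer ether chain at this place would keep the number clear of that of compound 1.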